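The source may hold more compounds than are shown below. What is called first, only, known or untested is meant among the compounds shown, and "the series" means these compounds.

Compound 1 `CCOC(=O)/C=C/c1ccncc1-c1ccc2c(ccn2C)c1`: 144 nM
Compound 2 `CNC(=O)/C=C/c1ccncc1-c1ccc2[nH]ccc2c1`: 51.9 nM
Compound 3 `CNC(=O)CCc1ccncc1-c1ccc2ccccc2c1`: 21.1 nM

These three compounds were tested in an assay on a protein complex for inhibition of CDK8/Cyclin C (Homo sapiens), with a stated time of 1 h; a higher number here means a weaker inhibitor, a lower number a stronger inhibitor. Compound 3 gives the lowest number of the three; compound 2 stands nearest to it and compound 1 furthest, and both gaps lie beyond the usual scatter. Compound 4 `O=C(/C=C/c1ccncc1-c1ccc2ccccc2c1)NC1CC1` has not been measured yet. It differs from compound 3 in one place: 2-(cyclopropylcarbamoyl)ethenyl in place of 2-(methylcarbamoyl)ethyl on an aromatic carbon. Among the measured compounds shown here, no step between measured compounds that differ in a single place is known here, so the effect of this change has to be judged from the structures alone. The step expected in this assay is small, a slight rise at most: a 1.4-fold higher number from compound 3 to compound 4 (0.15 log units; within the scatter). Compound 4 is therefore estimated at 30 nM, with a likely range from 10 nM to 90 nM.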

Compound 4, half-maximal inhibitory concentration: 40.1 nM
Compound 4: middle estimate off by 1.3-fold (0.13 log units), on the low side; the range from low to high includes it.
By their numbers in this assay, from the lowest: compounds 3, 4 and 2 (each within the scatter of the next, the first and the last beyond it); then compound 1.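

Putting 2-(cyclopropylcarbamoyl)ethenyl in place of 2-(methylcarbamoyl)ethyl on this carbon, opposite the ring nitrogen, gives a 1.9-fold higher number from compound 3 to compound 4 (0.28 log units; within the scatter). This first single-place comparison shows that the position takes the larger group, with its three-membered ring and extra double bond, while binding stays within the usual scatter. Nothing measured here gives a cause for this result.

From the compounds shown here alone, the swap alters the chain's double bond and the group on the amide nitrogen together, so the effect of each alone remains open. Also open, going by these compounds, is how a carboxylic acid or a longer chain would fare at this position.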